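Cyano for Carbamoyl on the Fluorinated Ring

The source may hold more compounds than are shown below. What is called first, only, known or untested is meant among the compounds shown, and "the series" means these compounds.

Compound 3 `N#Cc1cccc(C#Cc2cc(F)cc(C(N)=O)c2)n1` stands at the floor of what an assay on membranes from brain (strain Sprague-Dawley) for displacement of a labelled ligand from metabotropic glutamate receptor 5 (Rattus norvegicus), read by scintillation counting, with a stated time of 60 min (a lower number here means a stronger inhibitor, a higher number a weaker inhibitor), can report: in this assay compound 3 gives only > 10000 nM, a limit rather than a number. Compound 1 `N#Cc1cccc(C#Cc2cccc(C(N)=O)c2)n1` likewise gives only > 10000 nM, also a limit. Going by the values given here, both rest at the limit of > 10000 nM in this assay, at which 2 of the 3 values shown sit, so the one measured step, a step that the two limits leave unreadable from compound 1 to compound 3, cannot be read and offers no size for a change on the six-membered aromatic ring of carbon only. Among the compounds with values here, compound 2 `CCc1cccc(C#Cc2cccc(C#N)c2)n1`, which carries a cyano group on that ring and an ethyl group on the shared core, gives 3.4 nM in this assay; no step links it to compound 3 or compound 4, so its value shows only that a cyano-bearing member of this series can bind tightly. Compound 4 `N#Cc1cc(F)cc(C#Cc2cccc(C#N)n2)c1` differs from compound 3 by cyano in place of carbamoyl on an aromatic carbon. Within the data shown here, no measured step scales this change, so any expectation leans on compound 2 and its value of 3.4 nM. Compound 4 is expected to give 30 nM, in the range 5 nM to 300 nM. This would be an expected step of an at least 330-fold lower number from compound 3 to compound 4 (2.52 log units; beyond the scatter), toward stronger binding.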

Compound 4, inhibition constant: 2.7 nM
Beside the measured number, compound 4's estimate is 11-fold (1.05 log units) above it; the measured number lies below the stated range.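

Going by these compounds alone, the first readable step at this position is large: in this assay, cyano in place of carbamoyl on an aromatic carbon, meta to a fluoro group, gives an at least 3700-fold lower number from compound 3 to compound 4 (3.56 log units; beyond the scatter), beyond the scatter and toward stronger binding. The value of compound 3 is a limit and not a number, so this step has a bound rather than an exact size: the limit of > 10000 nM in this assay, at which 2 of the 4 values shown sit. Compound 4 gives 2.7 nM, which shows that tight binding is possible with a fluoro group on this ring and with the cyano group that compound 3 carries on the shared core.

The step of the fluoro group itself cannot be read, and the compounds shown do not tell what fluoro in place of hydrogen does when cyano is on the ring. They also leave open how a carboxylic acid or an amine at this position would fare.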